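The source may report more compounds than this note shows. Statements on the series, on what has been measured and on what is new or still open speak of the compounds shown alone.

Compound 3, with the structure `Cc1ccc(S(=O)(=O)N[C@@H](CC(=O)NC(C)(C)C)C(=O)NCCNC(=O)c2cc(Cl)ccc2Cl)cc1`, is the starting point of this step. In an ADME assay on HepG2 cells (Homo sapiens) for cytotoxicity (a lower number here means that less compound is needed, a higher number that more compound is needed for the effect), compound 3 gives > 11000 nM, which is a limit of the assay and not a measured number. Two close relatives share the same core. Compound 1, `Cc1ccc(S(=O)(=O)N[C@@H](CC(=O)NC(C)(C)C)C(=O)NCCNC(=O)c2cc(C)ccc2F)cc1`, in this assay gives > 11000 nM, again a limit. Compound 2, `Cc1ccc(S(=O)(=O)N[C@@H](CC(=O)NC(C)(C)C)C(=O)NCCNC(=O)c2ccccc2)cc1`, in this assay gives > 11000 nM, also a limit. All three sit at the limit of > 11000 nM in this assay, at which 3 of the 3 values shown sit, so the steps between them cannot be read: a step that the two limits leave unreadable from compound 1 to compound 2, a step that the two limits leave unreadable from compound 1 to compound 3 and a step that the two limits leave unreadable from compound 2 to compound 3.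

The new compound 4 has the structure `Cc1ccc(S(=O)(=O)N[C@@H](CC(=O)NC(C)(C)C)C(=O)NCCNC(=O)c2cc(Cl)ccn2)cc1`. It differs from compound 3 at one place: 4-chloropyridin-2-yl in place of 2,5-dichlorophenyl on a carbonyl carbon. The three measured steps change the ring on the same carbonyl carbon, and none of them moved any compound away from the limit, so they give no size and no direction to expect here. Since compound 3 and its relatives all stand at the limit, compound 4 is expected to stand there too, with an expected step that the limit leaves unreadable from compound 3 to compound 4. The estimate for compound 4 is therefore 20000 nM, in a range from 8000 nM to 60000 nM.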

Compound 4, half-maximal effective concentration: > 11000 nM
Compound 4 was reported as a limit; the forecaster's own chance of this, stated with the estimate: 85%; the middle value is on the limit's open side.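

In this assay compound 4 gives > 11000 nM, which is again a limit of the assay and not a measured number. The steps to compound 4 from compound 1, compound 2 and compound 3 therefore cannot be read, as all four stand together: the limit of > 11000 nM in this assay, at which 4 of the 4 values shown sit.

The compounds shown leave open how far apart these four compounds really lie, and whether any ring on this carbonyl carbon would give a measurable value.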